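Thiophene amide series: removing the cyanoacetyl group

The source may hold more compounds than are shown below. What is called first, only, known or untested is meant among the compounds shown, and "the series" means these compounds.

Compound 1 `N#Cc1c(N)sc(C(=O)Nc2ccc(Cl)cc2)c1-c1ccccc1` gives 650 nM in a functional assay on HT-29 cells (Homo sapiens) for inhibition, read by MTT assay; a higher number here means a weaker inhibitor, a lower number a stronger inhibitor. Compound 2 `N#CCC(=O)Nc1sc(C(=O)Nc2ccc(Cl)cc2)c(-c2ccccc2)c1C#N`, measured in the same way, gives 860 nM. The pair differs in one place: hydrogen in place of (cyanomethyl)carbonyl on a nitrogen on an aromatic ring. Among the measured compounds shown here, the step of a 1.3-fold lower number from compound 2 to compound 1 (0.12 log units; within the scatter) is the only measured instance of this change so far.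

Compound 3 `CCOC(=O)c1c(NC(=O)CC#N)sc(C(=O)Nc2ccccc2)c1-c1ccccc1` gives 630 nM in this assay. Its numbers sit alongside those of compound 1 and compound 2 without any of the gaps reaching beyond the scatter. The difference between the core of compound 3 and the core of compound 2 is not broken down here.

Compound 4 `CCOC(=O)c1c(N)sc(C(=O)Nc2ccccc2)c1-c1ccccc1` is not yet measured. It differs from compound 3 in one place: hydrogen in place of (cyanomethyl)carbonyl on a nitrogen on an aromatic ring. The place is described in the same words as for the change from compound 2 to compound 1, so this is the same change made on a different core.

Because the earlier step of a 1.3-fold lower number from compound 2 to compound 1 (0.12 log units; within the scatter) stayed within the scatter, the expected step of a 1.3-fold lower number from compound 3 to compound 4 (0.10 log units; within the scatter) is also small. For compound 4 the estimate in this assay is 500 nM, with an expected range from 250 nM to 1000 nM.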

Compound 4, half-maximal inhibitory concentration: 7490 nM
Compound 4: the middle estimate sits 15-fold (1.18 log units) below what was measured, outside the stated range (above it).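

Taking the (cyanomethyl)carbonyl off the nitrogen on the aromatic ring in this assay gives a 12-fold higher number from compound 3 to compound 4 (1.08 log units; beyond the scatter) on this core, so here the compound that keeps the group is the stronger inhibitor of the pair. The change therefore does not carry over as one fixed step between the two cores: the same change on two cores in this assay, a 1.3-fold lower number (0.12 log units; within the scatter) from compound 2 to compound 1 and a 12-fold higher number (1.08 log units; beyond the scatter) from compound 3 to compound 4, 16-fold (1.20 log units) apart, beyond the scatter of two such steps. This does not show which feature of the cores sets the two steps apart, since the cores differ from each other in more than one place and each offers a single pair, and it gives no rule for a third core.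

The compounds shown leave open whether the nitrile of the (cyanomethyl)carbonyl matters on the core of compound 3, which an acetyl group on the same nitrogen would test. Among the compounds shown here, also open is how the step behaves on a core that differs in only one place from the core of compound 1 or compound 3.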